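Permeability after swapping the nitrile ring in compound 1

The source may hold more compounds than are shown below. What is called first, only, known or untested is meant among the compounds shown, and "the series" means these compounds.

Measured so far:
compound 1 `N#Cc1ccccc1-c1cc(-c2cc(Cl)cc(OCCC(F)(F)F)c2)c(=O)n(-c2cccnc2)c1`: 4 10^-6 cm/s
compound 2 `Cc1ocnc1COc1cc(Cl)cc(-c2cc(-c3ccccc3C#N)cn(-c3cccnc3)c2=O)c1`: 3.04 10^-6 cm/s
compound 3 `Cc1ncoc1COc1cc(Cl)cc(-c2cc(-c3c[nH]c(=O)[nH]c3=O)cn(-c3cccnc3)c2=O)c1`: 0.24 10^-6 cm/s

In an ADME assay for permeability, using PAMPA, in phosphate buffer, with a stated time of 18 h, at pH 7.4 (on this read-out higher numbers stand for higher permeability and lower numbers for lower permeability), compound 1 gives the highest of the three numbers, though compound 2 sits within the scatter of it, as the step of a 1.3-fold lower number from compound 1 to compound 2 (0.12 log units; within the scatter) shows. Compound 3 stands far lower, beyond the scatter.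

Compound 4 `Cn1cc(-c2cc(-c3cc(Cl)cc(OCCC(F)(F)F)c3)c(=O)n(-c3cccnc3)c2)c(=O)[nH]c1=O` is not yet measured. It differs from compound 1 in one place: a group of 9 heavy atoms (5 carbon, 2 nitrogen, 2 oxygen; one six-membered aromatic ring with 2 hetero atoms) in place of a group of 8 heavy atoms (7 carbon, 1 nitrogen; one six-membered aromatic ring of carbon only), on an aromatic carbon

Going by the values given here, the one measured step, a 1.3-fold lower number from compound 1 to compound 2 (0.12 log units; within the scatter), changes a different part of the molecule and says little about this exchange. The closest comparison is compound 3, whose values show that a compound carrying a related group at the same position gives 0.24 10^-6 cm/s where compound 2 gives 3.04 10^-6 cm/s; these two are not a single-point pair, so the gap cannot be attributed to one change alone. Still, it points the same way. Compound 4 is therefore expected to fall well below compound 1 in this assay, a step estimated as a 5.7-fold lower number from compound 1 to compound 4 (0.76 log units; beyond the scatter). The estimate for compound 4 is 0.7 10^-6 cm/s, with a range from 0.25 10^-6 cm/s to 2 10^-6 cm/s.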

Compound 4, apparent permeability in the ADME assay: 2.26 10^-6 cm/s
Beside the measured number, compound 4's estimate is 3.2-fold (0.51 log units) below it, outside the stated range (above it).
By their numbers in the ADME assay, from the lowest: compound 3; then compounds 4, 2 and 1 (each within the scatter of the next).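

Going by these compounds alone, this is the first direct reading at this aromatic carbon, since the earlier compounds offered no pair differing only here. In the ADME assay, exchanging the 2-cyanophenyl group for the six-membered aromatic ring with 2 hetero atoms gives a 1.8-fold lower number from compound 1 to compound 4 (0.25 log units; within the scatter), so the two numbers cannot be told apart, even though the entering group carries 1 hydrogen-bond donor and 3 hydrogen-bond acceptors where the leaving group has 0 and 1. In a physicochemical assay for solubility, using the shake flask method, with a stated time of 48 h, at pH 6.5 (on this read-out lower numbers stand for lower solubility and higher numbers for higher solubility), compound 1 gives 25 ug/mL and compound 4 gives 57 ug/mL, so the same exchange does register, as a modest step beyond the scatter: the measured solubility of compound 1, 25 ug/mL, and of compound 4, 57 ug/mL, a 2.3-fold higher number (0.36 log units; beyond the scatter)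

In the ADME assay, compound 3 gives 0.24 10^-6 cm/s, but it differs from compound 4 in more than one place, so the shown compounds cannot tie that number to any single change. Also open is how a carboxylic acid or an amine on this same aromatic carbon would behave in the two assays, since no group of either kind appears among these compounds.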